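From 4-methylphenyl to 3-formylphenyl on a shared core

The compounds below may be only part of what the source reports. "The series", "measured", "known", "first", "only" and "open" are said of these compounds alone.

Of the compounds shown here, two with a shared core have numbers so far. In a functional assay on HepG2 cells (Homo sapiens) for inhibition, read by MTT assay, with a stated time of 48 h (a higher number here means a weaker inhibitor, a lower number a stronger inhibitor), compound 1 `COc1cc(C(=O)/C=C/c2ccc(F)cc2)cc(OC)c1OC` gives 22000 nM. Compound 2 `COc1cc(C(=O)/C=C/c2ccc(C)cc2)cc(OC)c1OC` gives 52000 nM, the higher number of the two, which makes it the weaker inhibitor here. The next structure is compound 3 `COc1cc(C(=O)/C=C/c2cccc(C=O)c2)cc(OC)c1OC`, and the change is this: 3-formylphenyl in place of 4-methylphenyl on a double-bonded chain carbon bound to a double-bonded chain carbon. Within the data shown here, only one measured step bears on it, a 2.4-fold higher number from compound 1 to compound 2 (0.37 log units; beyond the scatter). That modest step shows that a swap on this aromatic group can move the number beyond the scatter. Among the measured compounds shown here, no measured compound carries a formyl group, so the direction remains uncertain. With compound 2 at the top of this small range, a modest drop seems more likely than a further rise. The expected change is a 1.7-fold lower number from compound 2 to compound 3 (0.24 log units; within the scatter). For compound 3 the estimate is 30000 nM, with an expected range from 10000 nM to 80000 nM.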

Compound 3, half-maximal inhibitory concentration: > 100000 nM
Compound 3: only a limit was reported; the forecaster's own chance of this, stated with the estimate: 10%; at least 3.3-fold (0.52 log units) between middle value and limit.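

Compound 3 in this assay has no exact number, only a limit: the limit of > 100000 nM in this assay, at which 1 of the 3 values shown sits. Against compound 1 the step can still be read, as an at least 4.5-fold higher number from compound 1 to compound 3 (0.65 log units; beyond the scatter) shows that 3-formylphenyl in place of 4-fluorophenyl on this double-bonded chain carbon gives a weaker inhibitor, so this position can lose activity clearly and not only by the modest amount seen earlier. Against compound 2 the result is less firm, since an at least 1.9-fold higher number from compound 2 to compound 3 (0.28 log units; that floor lies within the scatter) gives only a floor and the true size of the change stays unknown.

Open, from the compounds shown here alone, is whether the formyl group itself or its place on the aromatic ring matters more, which a comparison of 4-formylphenyl and 3-methylphenyl could separate. Also open, going by these compounds, is how a phenyl ring carrying an amine or a carboxylic acid would read here.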